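The source may report more compounds than this note shows. Statements on the series, on what has been measured and on what is new or still open speak of the compounds shown alone.

Working notes on the series in a functional assay on PC-3 cells (Homo sapiens) for inhibition, read by sulforhodamine B assay, with a stated time of 72 h; a higher number here means a weaker inhibitor, a lower number a stronger inhibitor. Compound 1 (`Nc1sc(-c2ccc(Cl)cc2)c(-c2ccc(Cl)cc2)c1C(=O)NC1CCC(O)CC1`) gives 5670 nM, compound 2 (`Nc1sc(-c2ccc(Cl)cc2)c(-c2ccc(Cl)cc2)c1C(=O)N1CCOCC1`) gives 11700 nM, and compound 3 (`COc1ccc(CNC(=O)c2c(N)sc(-c3ccc(Cl)cc3)c2-c2ccc(Cl)cc2)cc1`) gives 29500 nM. Compound 3 has the highest number of the three, making it the weakest inhibitor here, and its gaps to both others lie beyond the scatter.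

The next compound is compound 4 (`Nc1sc(-c2ccc(Cl)cc2)c(-c2ccc(Cl)cc2)c1C(=O)N1CCNCC1`), in which piperazin-1-yl takes the place of (4-methoxybenzyl)amino on a carbonyl carbon: piperazin-1-yl in place of (4-methoxybenzyl)amino on a carbonyl carbon. Among the measured compounds shown here, the closest precedent is the morpholin-4-yl amide, compound 2, with a 2.5-fold higher number from compound 2 to compound 3 (0.40 log units; beyond the scatter), a modest step that runs opposite to the present change. Also relevant are a 5.2-fold higher number from compound 1 to compound 3 (0.72 log units; beyond the scatter) and a 2.1-fold higher number from compound 1 to compound 2 (0.31 log units; beyond the scatter), both modest. Thus, leaving (4-methoxybenzyl)amino lowered the number in the one comparable case, compound 2. For the measured compounds named here, no measured compound carries piperazin-1-yl, so this transfer is uncertain.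

A modest step towards a lower number is expected in this assay. The expected change is a 2.7-fold lower number from compound 3 to compound 4 (0.43 log units; beyond the scatter). For compound 4 the estimated value is 11000 nM, with an expected range of 4500 nM to 25000 nM.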

Compound 4, half-maximal inhibitory concentration: 2710 nM
Compound 4: the middle estimate sits 4.1-fold (0.61 log units) above what was measured, outside the stated range (below it).
By their numbers in this assay, from the lowest: compound 4; then compound 1; then compound 2; then compound 3.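

In this assay, among the compounds shown here, piperazin-1-yl on the carbonyl carbon gives the largest step so far (an 11-fold lower number from compound 3 to compound 4 (1.04 log units; beyond the scatter)), and compound 4 also sits beyond the scatter from the (4-hydroxycyclohexyl)amino amide (a 2.1-fold lower number from compound 1 to compound 4 (0.32 log units; beyond the scatter)), making it the strongest inhibitor of the four. For the compounds shown here, the comparison with morpholin-4-yl (a 4.3-fold lower number from compound 2 to compound 4 (0.64 log units; beyond the scatter)) shows that these two six-membered rings are not interchangeable at this position, which could not be seen from the earlier compounds. Nothing available accounts for these differences.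

The compounds shown leave open whether the ring nitrogen of piperazin-1-yl must remain unsubstituted, which 4-methylpiperazin-1-yl or 4-acetylpiperazin-1-yl would test. They also leave open whether piperidin-1-yl, with a ring carbon in place of that nitrogen, would stand closer to compound 4 or to compound 2.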